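This account rests on a few compounds, and the source may have more. Where it says the series, first, only, none or still open, it means among the compounds named here.

Compound 1 `CSc1ccccc1N1CCN(CCCCC(=O)N2CCC[C@H]2C(N)=O)CC1` is tested in an assay on HEK293 cells for displacement of a labelled ligand from 5-hydroxytryptamine receptor 7 (Homo sapiens), with a stated time of 1 h (on this read-out higher numbers stand for weaker inhibition and lower numbers for stronger inhibition), where compound 1 gives 163 nM. Compound 2 `COc1ccccc1N1CCN(CCCCCC(=O)N2Cc3ccccc3C[C@H]2C(N)=O)CC1` is tested in the same way, and in this assay compound 2 gives 302 nM, a value lying within the usual scatter of the value of compound 1, so the two cannot be set apart on these numbers. Compound 3 `NC(=O)[C@@H]1Cc2ccccc2CN1C(=O)CCCCCN1CCN(c2ccccc2Cl)CC1` differs from compound 2 by chloro in place of methoxy on an aromatic carbon. Among the measured compounds shown here, no measured pair shows this exchange here, so the step from compound 2 to compound 3 in this assay is expected to be small, if anything toward a higher number, and a 1.7-fold higher number from compound 2 to compound 3 (0.22 log units; within the scatter) is the estimated step. For compound 3 the expected value is 500 nM, estimated to lie between 150 nM and 1600 nM.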

Compound 3, inhibition constant: 393 nM
Compound 3: the middle estimate sits 1.3-fold (0.10 log units) above what was measured; low and high end bracket the measured number.
By their numbers in this assay, from the lowest: compounds 1, 2 and 3 (each within the scatter of the next, the first and the last beyond it).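

In this assay, chloro in place of methoxy on the aromatic carbon ortho to a large group gives a 1.3-fold higher number from compound 2 to compound 3 (0.11 log units; within the scatter). The methoxy takes its hydrogen-bond acceptor with it, yet compound 2 and compound 3 cannot be set apart on these numbers, so this exchange at this position shows no measurable effect here. No available evidence bears on this result. From the compounds shown here alone, whether an amine or a carboxylic acid at this position would give a clear step remains open. So does whether the same exchange would behave alike on the core of compound 1.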